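Lengthening the Alkoxy Arm of Compound 2

The source may report more compounds than this note shows. Statements on the series, on what has been measured and on what is new or still open speak of the compounds shown alone.

Compound 2 `COCC(=N)NCCC[C@H](N)C(=O)O` gives 75% in an assay on isolated protein for inhibition of Nitric oxide synthase, inducible (Homo sapiens), read by spectrophotometry, using NADPH, tested at 1 mM, in the presence of a further agent that is not named here (a higher number here means more inhibition at the concentration tested (going by the name of the read-out), a lower number less inhibition), the highest of the three numbers recorded and beyond the scatter from both others. Compound 3 `COCC(=N)NCCCCN` gives 42%, and compound 1 `CCCCCNC(=N)NCCOC` gives 21%. Among the compounds with values here, the only single-place step in the set, a number 33 percentage points lower from compound 2 to compound 3 (beyond the scatter), alters a different part of the molecule and so does not speak to the present change. Compound 4 `COCCCC(=N)NCCC[C@H](N)C(=O)O` carries 2-methoxyethyl in place of methoxy on a saturated chain carbon bound to a carbon with a double bond to nitrogen. Within the data shown here, no measured pair isolates this lengthening; compound 1 also holds a 2-methoxyethyl group but differs from compound 2 in more than one place, so its value cannot be read as a guide. Compound 4 is therefore expected to give about 62%, between 30% and 85%. The expected step is a number 13 percentage points lower from compound 2 to compound 4 (beyond the scatter), not beyond the scatter.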

Compound 4, a percentage reported as inhibition, at one concentration (the size of the read-out at that concentration, not a potency): 26%
Compound 4: middle estimate off by 36 percentage points, on the high side; measured number below the stated range.
By their numbers in this assay, from the lowest: compounds 1 and 4 (each within the scatter of the next); then compound 3; then compound 2.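

In this assay this position proves sensitive to the length of the arm: with 2-methoxyethyl in place of methoxy, the result is a number 49 percentage points lower from compound 2 to compound 4 (beyond the scatter). Within the data shown here, the earlier single-place step concerned a different part of the molecule, so this is the first sign that the saturated chain carbon bound to a carbon with a double bond to nitrogen also governs the read-out, even with the amino acid portion unchanged. Nothing available explains this drop. On these data alone, whether it follows from the added chain length or from where the ether oxygen sits remains open. A plain butyl chain, with no ether oxygen, or an ethoxy group at this place would help separate the two.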